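The source may report more compounds than this note shows. Statements on the series, on what has been measured and on what is new or still open speak of the compounds shown alone.

Measured so far in a functional assay on KB cells (Homo sapiens) for cytotoxicity, read by MTT assay, with a stated time of 72 h; a lower number here means a stronger inhibitor, a higher number a weaker inhibitor:
- compound 1 `Cc1ccc(S(=O)(=O)c2nc3ccccc3nc2N2CCCC(O)C2)cc1`: 6080 nM
- compound 2 `O=S(=O)(c1ccc(Br)cc1)c1nc2ccccc2nc1N1CCCC(O)C1`: 3720 nM

With only these two numbers, compound 1 has no clear rank: it lies within the scatter of compound 2, and the step between them is a 1.6-fold lower number from compound 1 to compound 2 (0.21 log units; within the scatter). Compound 3 `Cc1ccc(S(=O)(=O)c2nc3ccccc3nc2N2CCC(O)CC2)cc1` is the next compound to be read in this assay. Compared with compound 1, it has the same atoms joined differently: 4-hydroxypiperidin-1-yl in place of 3-hydroxypiperidin-1-yl on an aromatic carbon. The change is 4-hydroxypiperidin-1-yl in place of 3-hydroxypiperidin-1-yl on an aromatic carbon, with the ring attachment on the shared core unchanged.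

For the measured compounds named here, the one measured step, a bromo in place of methyl on an aromatic carbon, leaves the hydroxypiperidine untouched, so it bears only indirectly. It shows that one change to the core of compound 1 stayed within the scatter, as a 1.6-fold lower number from compound 1 to compound 2 (0.21 log units; within the scatter). Going by the values given here, no measured pair tests the hydroxyl position, so no direction is supported. The expected result is no step beyond the scatter, and the estimate is a 1.2-fold lower number from compound 1 to compound 3 (0.08 log units; within the scatter). For compound 3 the expected value is 5000 nM, with an estimated range of 2000 nM to 13000 nM.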

Compound 3, half-maximal inhibitory concentration: 6140 nM
For compound 3 the middle estimate is 1.2-fold (0.09 log units) below the measured one; low and high end bracket the measured number.
By their numbers in this assay, from the lowest: compounds 2, 1 and 3 (each within the scatter of the next).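

In this assay, for the compounds shown here, 4-hydroxypiperidin-1-yl in place of 3-hydroxypiperidin-1-yl on the shared core gives a 1.0-fold higher number from compound 1 to compound 3 (0.00 log units; within the scatter), and this pair is the first measured test of where the hydroxyl sits on the piperidine ring. The two groups have the same atoms and the same counts of donors and acceptors, and with the methyl kept on the aromatic ring this assay does not separate them, so either hydroxypiperidine can stand at this aromatic carbon without a step beyond the scatter. Both single changes now measured on compound 1, this one and the earlier 1.6-fold lower number from compound 1 to compound 2 (0.21 log units; within the scatter), lie within the scatter, and no supporting data are available to explain this result.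

The compounds shown leave open whether 4-hydroxypiperidin-1-yl gives the same reading when bromo replaces methyl on the aromatic ring, since that combination is outside this set. They also leave open whether a different group on the piperidine ring, such as an amine or a carboxylic acid, or a different ring at this carbon, such as morpholine, would give a step beyond the scatter.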